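This account rests on a few compounds, and the source may have more. Where it says the series, first, only, none or still open, it means among the compounds named here.

Measured in a functional assay on KB cells (Homo sapiens) for cytotoxicity, read by MTT assay, with a stated time of 72 h; on this read-out lower numbers stand for stronger inhibition and higher numbers for weaker inhibition:

- Compound 1 `Cc1ccc(S(=O)(=O)c2nc3ccccc3nc2N2CCCC2)cc1`: > 50000 nM (a limit)
- Compound 2 `O=S(=O)(c1ccc(Br)cc1)c1nc2ccccc2nc1N1CCCC1`: > 50000 nM (a limit)
- Compound 3 `O=S(=O)(c1ccccc1)c1nc2ccccc2nc1N1CCc2ccccc2C1`: 26300 nM

Going by the values given here, compound 3 holds the only true number in this small set. Everything else shown is the limit of > 50000 nM in this assay, at which 2 of the 3 values shown sit.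

Compound 4 `Cc1ccc(S(=O)(=O)c2nc3ccccc3nc2N2CCc3ccccc3C2)cc1` differs from compound 3 in one place: methyl in place of hydrogen on an aromatic carbon. This is methyl in place of hydrogen on an aromatic carbon, which turns phenyl into 4-methylphenyl.

Among the compounds with values here, the only measured step at a comparable place is a step that the two limits leave unreadable from compound 1 to compound 2, so it offers no size to carry over to this change. With no readable step to draw on, the expectation stays close to compound 3 at 26300 nM in this assay, with no shift in either direction beyond the usual scatter. The expected step is a 1.1-fold higher number from compound 3 to compound 4 (0.06 log units; within the scatter). Compound 4 is estimated at about 30000 nM, with an expected range from 13000 nM to 50000 nM.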

Compound 4, half-maximal inhibitory concentration: 32100 nM
The estimate for compound 4 lay 1.1-fold (0.03 log units) below the measured number, within the range that was stated.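

In this assay, the first readable size for a change at this place on the aromatic ring is small: methyl in place of hydrogen gives a 1.2-fold higher number from compound 3 to compound 4 (0.09 log units; within the scatter), so the 4-methylphenyl group leaves the number where phenyl had it. Putting 1,2,3,4-tetrahydroisoquinolin-2-yl in place of pyrrolidin-1-yl gives an at least 1.5-fold lower number from compound 1 to compound 4 (0.19 log units; that floor lies within the scatter), which is only a floor on the step. Compound 1 carries a limit and not a true number, so the real size of that step cannot be told: the limit of > 50000 nM in this assay, at which 2 of the 4 values shown sit.

The step from compound 1 to compound 2 cannot be read, so bromo remains without a size at this place. On these data alone, whether a carboxylic acid, an amine or a longer chain at this same place would move the number beyond the scatter stays open.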